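Amide Side Chain Shortened: Expected Tolerance in Cytotoxicity

The source may hold more compounds than are shown below. What is called first, only, known or untested is meant among the compounds shown, and "the series" means these compounds.

Compound 1 `COc1cc(CNC(=O)c2cc3nc(C)c([C@H](OC(C)(C)C)C(=O)O)c(-c4cc(F)c5c(c4C)CCCO5)n3n2)ccc1F` was examined in an ADME assay on MT2 cells (Homo sapiens) for cytotoxicity; a lower number here means that less compound is tolerated, a higher number that more compound is tolerated. In this assay compound 1 gives only > 20000 nM, a limit of the assay rather than a number. Compound 1 thus sits at the limit of > 20000 nM in this assay, at which 1 of the 2 values shown sits. Compound 2 `Cc1nc2cc(C(=O)NCc3ccc(F)cc3N3CCCC3=O)nn2c(-c2cc(F)c3c(c2C)CCCO3)c1[C@H](OC(C)(C)C)C(=O)O` likewise gives only a limit, > 40000 nM. Compound 3 `CCCNC(=O)c1cc2nc(C)c([C@H](OC(C)(C)C)C(=O)O)c(-c3cc(F)c4c(c3C)CCCO4)n2n1` differs from compound 1 by ethyl in place of 4-fluoro-3-methoxyphenyl on a saturated chain carbon bound to an amide-type nitrogen. For the measured compounds named here, no measured step covers this change. The step that the limit leaves unreadable from compound 1 to compound 3 is expected to stay within the scatter, with no shift beyond it. For compound 3 a half-maximal cytotoxic concentration of 30000 nM is estimated, spanning 12000 nM to 80000 nM, and most likely again reported only as a limit.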

Compound 3, half-maximal cytotoxic concentration: > 40000 nM
Compound 3: no number, only a limit (the forecaster's own chance of this, stated with the estimate: 85%); middle value at least 1.3-fold (0.12 log units) from the limit.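

For the compounds shown here, compound 1 and compound 3 both give only limits in this assay, so no step between them can be read. The compounds shown leave open where their true half-maximal cytotoxic concentrations lie.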